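From Compound 2 to Compound 3: Trifluoromethyl to Bromo

This account rests on a few compounds, and the source may have more. Where it says the series, first, only, none or still open, it means among the compounds named here.

In a functional assay on PANC-1 cells (Homo sapiens) for inhibition, read by MTT assay, with a stated time of 24 h, tested at 10 uM (on this read-out higher numbers stand for more inhibition at the one concentration tested (going by the name of the read-out) and lower numbers for less inhibition), compound 1 `CC(C)=CCC1Cc2c(OCc3ccccc3)cc(=O)n(CCCO)c2CC1(C)C` gives 11.1%, while compound 2 `CC(C)=CCC1Cc2c(OCCCNS(=O)(=O)c3ccc(C(F)(F)F)cc3)cc(=O)n(CCCO)c2CC1(C)C` gives 0%, the lowest of the two numbers; the gap to compound 1 lies beyond the usual scatter. Compound 3 `CC(C)=CCC1Cc2c(OCCCNS(=O)(=O)c3ccc(Br)cc3)cc(=O)n(CCCO)c2CC1(C)C` has not yet been measured. It differs from compound 2 in one place: bromo in place of trifluoromethyl on an aromatic carbon. Within the data shown here, with only two measured compounds, and no pair among them that differs in a single place, there is nothing in this assay to calibrate how such an exchange on this aromatic ring moves the read-out. The counted difference shows no change in hydrogen-bond donors or acceptors. In this assay compound 3 is expected to show no shift beyond the scatter, and the step from compound 2 to compound 3 is estimated as a number 3 percentage points higher from compound 2 to compound 3 (within the scatter). Compound 3 is therefore expected to give about 3%, between 0% and 15%.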

Compound 3, a percentage reported as inhibition, at one concentration (the size of the read-out at that concentration, not a potency): 3.7%
Estimate against measurement, compound 3: 0.7 percentage points below; low and high end bracket the measured number.
By their numbers in this assay, from the lowest: compounds 2, 3 and 1 (each within the scatter of the next, the first and the last beyond it).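

In this assay, among these compounds, the exchange of trifluoromethyl for bromo gives a number 3.7 percentage points higher from compound 2 to compound 3 (within the scatter), the first step that can be read at a single place. On this aromatic carbon, para to a large group, the read-out therefore does not separate these two groups at the one concentration tested. Nothing available here accounts for this result.

The compounds shown leave open whether an amine or a carboxylic acid on this same aromatic carbon would move the read-out beyond the scatter, as neither group appears among them. They also leave open what a longer chain would do in place of the one that carries the sulfonamide, with either the 4-bromophenyl or the 4-(trifluoromethyl)phenyl group at its end.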